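Chain Extension of Hydroxamic Acids on Two Related Cores

A few compounds are considered here, and "the series" means these few. Any claim that something is new, unique, unknown or untested is made for them only; others in the source may bear on it.

The series is examined in a functional assay on CNE-2 cells (Homo sapiens) for inhibition, read by MTT assay, with a stated time of 72 h; a lower number here means a stronger inhibitor, a higher number a weaker inhibitor. Compound 1 `Nc1ncnc2c1c(-c1cnc3[nH]ccc3c1)nn2CCCCC(=O)NO` is measured in this assay, and compound 1 gives > 150000 nM, which is a limit of the assay and not a number. Compound 3 `Nc1ncnc2c1c(-c1cnc3[nH]ccc3c1)nn2CCCCCCC(=O)NO` carries the longer chain, and in this assay compound 3 gives 19500 nM. The change between them is 2-(hydroxycarbamoyl)ethyl in place of hydroxycarbamoyl on a saturated chain carbon, four bonds along the chain from an aromatic nitrogen, and it makes an at least 7.6-fold lower number from compound 1 to compound 3 (0.88 log units; beyond the scatter); the step is stated only as a lower bound because of the limit of > 150000 nM in this assay, at which 2 of the 3 values shown sit.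

Compound 2 `Nc1nc2cc(-c3nn(CCC(=O)NO)c4ncnc(N)c34)ccc2o1` rests on a different core; the difference between the two cores is not broken down here. In this assay compound 2 gives > 150000 nM, which is again a limit of the assay rather than a number.

Compound 4 `Nc1nc2cc(-c3nn(CCCCC(=O)NO)c4ncnc(N)c34)ccc2o1` has not been measured. It differs from compound 2 by 2-(hydroxycarbamoyl)ethyl in place of hydroxycarbamoyl on a saturated chain carbon, two bonds along the chain from an aromatic nitrogen. This is the same kind of change as that from compound 1 to compound 3, but the place is not identical: there the group sits four bonds along the chain from an aromatic nitrogen, here two bonds along the chain from an aromatic nitrogen. The shorter overall chain of compound 4 resembles that of compound 1, which itself reached only a limit, so only a small gain is expected, estimated as an at least 1.5-fold lower number from compound 2 to compound 4 (0.17 log units; that floor lies within the scatter). Compound 4 is therefore expected to give about 100000 nM, within 20000 nM to 300000 nM, with a real chance that only a limit is reported.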

Compound 4, half-maximal inhibitory concentration: > 50000 nM
Compound 4: a limit, no number; the forecaster's own chance of this, stated with the estimate: 45%; the middle value lies beyond the limit too.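

In this assay compound 4 gives > 50000 nM, which is a limit of the assay and not a number. For the compounds shown here, compound 2 also stands at a limit, so no step from compound 2 to compound 4 can be read. The compounds shown leave open whether the longer chain lowers the number on the core of compound 2, as it does from compound 1 to compound 3 on their core.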